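The source may report more compounds than this note shows. Statements on the series, on what has been measured and on what is new or still open speak of the compounds shown alone.

Working notes on the series. In a functional assay on MCF7 cells (Homo sapiens) for inhibition, read by MTT assay, with a stated time of 48 h (on this read-out higher numbers stand for weaker inhibition and lower numbers for stronger inhibition), compound 1 (`CCOC(=O)C1=C(N/N=C(\C#N)C(N)=O)Nc2[nH]nc(C)c2C1c1ccc(N(C)C)cc1`) gives 50100 nM and compound 2 (`CCOC(=O)C1=C(N/C=N/c2ccc(C)cc2)Nc2[nH]nc(C)c2C1c1ccc(N(C)C)cc1`) gives 50500 nM on the same read-out, so compound 2 stands level with compound 1 within the scatter. Compound 3 (`CCOC(=O)C1=C(N/N=C(/C(=O)Br)c2ccc(Cl)cc2)Nc2[nH]nc(C)c2C1c1ccc(N(C)C)cc1`) has not been measured yet. Its difference from compound 2 reads a group of 12 heavy atoms (8 carbon, 1 nitrogen, 1 oxygen, 1 chlorine, 1 bromine; one six-membered aromatic ring of carbon only) in place of a group of 9 heavy atoms (8 carbon, 1 nitrogen; one six-membered aromatic ring of carbon only), on an amine nitrogen in full, on an amine nitrogen whose other neighbours are: double-bonded ring carbon. Both groups hold one six-membered aromatic ring of carbon only.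

Going by the values given here, one measured step bears on this, a change of group on an amine nitrogen: a 1.0-fold higher number from compound 1 to compound 2 (0.00 log units; within the scatter) and it lies within the scatter. That single step is a thin guide, since neither compound 1 nor compound 2 carries chlorine or bromine. No step beyond the scatter is therefore expected in this assay for this change. The estimated move is a 1.3-fold lower number from compound 2 to compound 3 (0.10 log units; within the scatter) and it is expected to stay within the scatter. Compound 3 is expected at 40000 nM with an estimated range from 12000 nM to 100000 nM on this read-out.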

Compound 3, half-maximal inhibitory concentration: 46300 nM
For compound 3 the middle estimate is 1.2-fold (0.06 log units) below the measured one; the measured number falls inside the stated range.
By their numbers in this assay, from the lowest: compounds 3, 1 and 2 (each within the scatter of the next).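

In this assay the change on the amine nitrogen whose other neighbours are: double-bonded ring carbon gives a 1.1-fold lower number from compound 2 to compound 3 (0.04 log units; within the scatter) when the group of 9 heavy atoms leaves and a 1.1-fold lower number from compound 1 to compound 3 (0.03 log units; within the scatter) when the group of 7 heavy atoms with no ring leaves, so neither step separates compound 3 from the two earlier compounds. Compound 1 and compound 2 stood level with groups free of halogen, and compound 3 extends that level reading to a group of 12 heavy atoms that carries chlorine and bromine, with 2 double bonds outside aromatic rings and 2 hydrogen-bond acceptors. No measurement beyond these read-outs speaks to why the three numbers stand level.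

Whether any group at this amine nitrogen can move the number beyond the scatter remains open, since the three groups shown give no such step and all three compounds share the rest of the core. A carboxylic acid, a free amine or a longer alkyl chain at this nitrogen would show whether the level reading holds for groups unlike these three.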